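Acetyl on the oxygen of compound 2: what cytotoxicity may do

The compounds below may be only part of what the source reports. "The series", "measured", "known", "first", "only" and "open" are said of these compounds alone.

Measured in an ADME assay on MT2 cells (Homo sapiens) for cytotoxicity; a lower number here means that less compound is tolerated, a higher number that more compound is tolerated:
- compound 1 `CNCc1cc(N)c(Nc2ccc(C#N)cc2)cc1Oc1c(C)cc(C#N)cc1C`: 12700 nM
- compound 2 `COCc1cc(N)c(Nc2ccc(C#N)cc2)cc1Oc1c(C)cc(C#N)cc1C`: 146000 nM

Of the two measured compounds, compound 2 stands highest at 146000 nM, so it tolerates more compound than compound 1 at 12700 nM. The next structure is compound 3 `CC(=O)OCc1cc(N)c(Nc2ccc(C#N)cc2)cc1Oc1c(C)cc(C#N)cc1C`, and it differs from compound 2 as follows: acetyl in place of methyl on an oxygen on a saturated carbon. Methoxymethyl thus becomes acetoxymethyl.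

Among the measured compounds shown here, only one measured step bears on this place: an 11-fold higher number from compound 1 to compound 2 (1.06 log units; beyond the scatter). For the measured compounds named here, that step is large, but it exchanges methylamino for methoxy, which is a different change from the one in compound 3. It shows that the number in this assay can move strongly at this place, but it does not fix the size or direction of an acetyl change. A moderate fall, smaller than that measured step, is expected, though with little support from so few data. The expected step is a 2.1-fold lower number from compound 2 to compound 3 (0.32 log units; beyond the scatter). For compound 3 the estimated value is 70000 nM, with an expected range from 20000 nM to 200000 nM.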

Compound 3, half-maximal cytotoxic concentration: 113000 nM
For compound 3 the middle estimate is 1.6-fold (0.21 log units) below the measured one, and the stated range covers the measured number.
By their numbers in this assay, from the lowest: compound 1; then compounds 3 and 2 (each within the scatter of the next).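

In this assay the step of a 1.3-fold lower number from compound 2 to compound 3 (0.11 log units; within the scatter) puts acetyl and methyl on this oxygen within the scatter of each other, so the larger group, with its added hydrogen-bond acceptor, gives a number that cannot be told apart from that of methyl. The step of an 8.9-fold higher number from compound 1 to compound 3 (0.95 log units; beyond the scatter) sets acetoxy clear of methylamino on the same saturated chain carbon, and so the gap first seen with methoxy is now seen with a second oxygen-linked group, leaving compound 1 as the only one of the three set apart. Nothing measured here gives a reason for either step.

The compounds shown leave open whether this flat reading holds for other groups on the oxygen, such as a bare hydrogen that would make a free alcohol, or a longer acyl chain such as butanoyl. They also leave open whether the low number of compound 1 belongs to methylamino alone or would also appear with another amine, such as dimethylamino, or with a carboxylic acid at this place.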